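This account rests on a few compounds, and the source may have more. Where it says the series, first, only, none or still open, it means among the compounds named here.

Measured compounds:
compound 1, `O=C(O)Cc1sc(C(c2ccccc2)c2ccccn2)nc1-c1ccc(Cl)cc1`, 1900 nM
compound 2, `O=C(O)Cc1sc(C(c2ccc(F)cc2)c2ccc(F)cc2)nc1-c1ccccc1`, 240 nM
compound 3, `O=C(O)Cc1sc(C(c2ccccc2)c2ccccc2)nc1-c1cccc(F)c1`, 29 nM

Three compounds sharing one core were measured in an in vitro functional assay on HEK285-7 cells for antagonist activity at prostaglandin D2 receptor 2 (Homo sapiens), read by BRET and beta-arrestin recruitment; on this read-out lower numbers stand for stronger inhibition and higher numbers for weaker inhibition. Compound 1 gives 1900 nM, compound 3 gives 29 nM, and compound 2 gives 240 nM. On these three numbers compound 2 stands second highest: its nearest neighbour is compound 1, whose higher number lies beyond the scatter, and the gap to compound 3, whose number is lower, is also beyond the scatter.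

The unmeasured compound 4, `O=C(O)Cc1sc(C(c2ccc(F)cc2)c2ccc(F)cc2)nc1-c1ccnc(N2CCC2)c1`, is derived from compound 2 by one change at the aryl group on the core, (2-(azetidin-1-yl)pyridin-4-yl in place of phenyl on an aromatic carbon). Within the data shown here, no measured pair in this set shows the effect of such a change, so the direction and size of the step from compound 2 to compound 4 cannot be read from the data. The expectation is therefore a guarded one: a modest move toward a lower number, a 1.6-fold lower number from compound 2 to compound 4 (0.20 log units; within the scatter), not far beyond the scatter. For compound 4 the estimated value in this assay is 150 nM, with an expected range from 40 nM to 600 nM.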

Compound 4, half-maximal inhibitory concentration: > 100000 nM
Compound 4: a limit, no number; the forecaster's own chance of this, stated with the estimate: 3%; at least 660-fold (2.82 log units) between middle value and limit.
By their numbers in this assay, from the lowest: compound 3; then compound 2; then compound 1. At a limit, above all of these: compound 4.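

In this assay compound 4 stands at a limit of the assay and not at a number: the limit of > 100000 nM in this assay, at which 1 of the 4 values shown sits.

At this place on the shared core, an aromatic carbon next to the ring nitrogen and next to the ring atom that bears a carboxymethyl group, 2-(azetidin-1-yl)pyridin-4-yl in place of phenyl gives an at least 410-fold higher number from compound 2 to compound 4 (2.61 log units; beyond the scatter). Among these compounds, this is the first change at this place that can be read on its own, and it shows that the place does not accept every aryl group, since this one replacement takes the read-out out of measurable range. Among the compounds shown here, compound 1, compound 2 and compound 3 all carry a carbon-only aromatic ring here, plain or with a halogen, and they differ in more than one place, so no step among them can be read.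

The compounds shown do not separate the pyridine ring nitrogen from the azetidine as the part tied to this loss, a question that an unsubstituted pyridin-4-yl or a phenyl bearing an azetidin-1-yl group would address. They also leave open whether a smaller substituent on the pyridine, such as a methyl or a methoxy group, would keep the read-out measurable.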